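A few compounds are considered here, and "the series" means these few. Any claim that something is new, unique, unknown or untested is made for them only; others in the source may bear on it.

In a functional assay on A549 cells (Homo sapiens) for inhibition, read by MTT assay, with a stated time of 72 h (on this read-out lower numbers stand for stronger inhibition and higher numbers for weaker inhibition), compound 2 `COc1ccccc1-c1csc2cnc(Nc3ccc(NC(=O)[C@@H]4CCCNC4)cc3)nc12` gives 410 nM and compound 1 `COc1ccccc1-c1csc2cnc(Nc3ccc(NC(=O)C4CCNCC4)cc3)nc12` gives 450 nM, so the two sit together at the low end of the numbers, while compound 3 `COc1ccccc1-c1csc2cnc(Nc3ccc(C(=O)NC4CCNCC4)cc3C)nc12` stands clearly higher at 3420 nM. Compound 4 `CNC(=O)c1ccc(Nc2ncc3scc(-c4ccccc4OC)c3n2)cc1` is still unmeasured. Its change from compound 2 is methylcarbamoyl in place of ((piperidin-3-yl)carbonyl)amino on an aromatic carbon. For the measured compounds named here, the only measured single-place step, a 1.1-fold lower number from compound 1 to compound 2 (0.04 log units; within the scatter), merely swaps one piperidinyl group for another, and no measured step removes that ring. Compound 4 has its carbonyl directly on the aromatic carbon, as does the nearest guide, compound 3, which gives 3420 nM. The expected step in this assay is a 7.3-fold higher number from compound 2 to compound 4 (0.86 log units; beyond the scatter), toward a higher number and beyond the scatter. The estimate for compound 4 is 3000 nM, with an expected range from 800 nM to 10000 nM.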

Compound 4, half-maximal inhibitory concentration: 310 nM
Compound 4: middle estimate off by 9.7-fold (0.99 log units), on the high side; measured number below the stated range.
By their numbers in this assay, from the lowest: compounds 4, 2 and 1 (each within the scatter of the next); then compound 3.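

In this assay the change to methylcarbamoyl gives a 1.3-fold lower number from compound 2 to compound 4 (0.12 log units; within the scatter) and a 1.5-fold lower number from compound 1 to compound 4 (0.16 log units; within the scatter) for the two piperidine-bearing groups. At this position on the aromatic carbon, then, neither the six-membered non-aromatic ring nor the defined stereocentre is needed to keep the number where it is, and a much smaller group serves as well. Nothing available explains why this change leaves the number in place. Still open, from the compounds shown here alone, is whether a carboxylic acid, a simple amine or a longer chain at this position would do the same.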